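A Selenium Swap on a Fused Aminated Core

This account rests on a few compounds, and the source may have more. Where it says the series, first, only, none or still open, it means among the compounds named here.

Compound 1 `Sc1nc(NCc2ccccc2)c2ccccc2n1` was tested in a functional assay on CCRF-CEM cells (Homo sapiens) for cytotoxicity, read by MTT assay, with a stated time of 72 h (on this read-out lower numbers stand for stronger inhibition of growth and higher numbers for weaker inhibition of growth), where compound 1 gives 82400 nM. Going by the values given here, this is the only number so far; the other result is a limit of the assay. Compound 2 `COc1ccc(CNc2nc(SC)nc3ncccc23)cc1` sits at that limit, since in this assay compound 2 gives > 100000 nM. Among the compounds with values here, the picture of the series so far is summed up by the limit of > 100000 nM in this assay, at which 1 of the 2 values shown sits. Compound 3 `C[Se]c1nc(NCc2ccccc2)c2ccccc2n1` has not yet been tested. It differs from compound 1 in one place: a group of 2 heavy atoms (1 carbon, 1 selenium; no ring) in place of one sulfur atom, on an aromatic carbon. Within the data shown here, with no measured step for a change of this kind, the expected step of a 1.0-fold lower number from compound 1 to compound 3 (0.01 log units; within the scatter) is small, not beyond the usual scatter, in either direction. Compound 3 is therefore estimated at 80000 nM, with a likely range from 30000 nM to 160000 nM.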

Compound 3, concentration for 50% growth inhibition: 39800 nM
Beside the measured number, compound 3's estimate is 2.0-fold (0.30 log units) above it; low and high end bracket the measured number.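

In this assay, placing a group of 2 heavy atoms (1 carbon, 1 selenium; no ring) in place of the sulfanyl group, on the aromatic carbon between two ring nitrogen atoms, gives a 2.1-fold lower number from compound 1 to compound 3 (0.32 log units; beyond the scatter), so the number at this position does respond to a change. The swap alters more than one thing at once, since selenium replaces sulfur, a carbon is added, and the hydrogen-bond donor and acceptor counted for sulfanyl are gone, so the step cannot be credited to selenium alone. Compound 2, which differs from the others in more than one place, remains at a limit of the assay: the limit of > 100000 nM in this assay, at which 1 of the 3 values shown sits.

Going by these compounds, whether an amine or a longer chain on selenium at this position would move the number further remains open. Also open, on these data alone, is whether the same swap would give a similar step on a different core.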